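The source may report more compounds than this note shows. Statements on the series, on what has been measured and on what is new or still open speak of the compounds shown alone.

Measured so far:
compound 1, `CCCCCCCCCCCCNC(=O)[C@@H](NC(=O)c1cccs1)[C@@H](C)O` — in a functional assay on SW-620 cells (Homo sapiens) for cytotoxicity, read by MTT assay, with a stated time of 48 h (on this read-out higher numbers stand for weaker inhibition and lower numbers for stronger inhibition), compound 1 gives 29200 nM;
compound 2, `CCCCCCCCCCCCNC(=O)[C@@H](NS(=O)(=O)c1ccc(C)cc1)[C@@H](C)O` — in this assay compound 2 gives 25600 nM.

Compound 2 has the lower of the two numbers, but the step of a 1.1-fold lower number from compound 1 to compound 2 (0.06 log units; within the scatter) is within the scatter, so compounds 1 and 2 are not distinguished by this assay.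

The unmeasured compound 3, `CCCCCCCCCCCCNC(=O)[C@@H](NS(=O)(=O)c1cccs1)[C@@H](C)O`, differs from compound 2 by thiophen-2-yl in place of 4-methylphenyl on a sulfonyl sulfur. Among the compounds with values here, the only measured step that bears on this change is a 1.1-fold lower number from compound 1 to compound 2 (0.06 log units; within the scatter), which combined a thiophen-2-yl to 4-methylphenyl swap with a carbonyl to sulfonyl swap and produced no movement beyond the scatter. Nothing measured here speaks for a move in either direction, so no step beyond the scatter is expected: compound 3 is estimated at 27000 nM, with a range of 12000 nM to 60000 nM, meaning an expected step of a 1.1-fold higher number from compound 2 to compound 3 (0.02 log units; within the scatter).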

Compound 3, half-maximal inhibitory concentration: 27900 nM
Compound 3: middle estimate off by 1.0-fold (0.01 log units), on the low side; the measured number falls inside the stated range.
By their numbers in this assay, from the lowest: compounds 2, 3 and 1 (each within the scatter of the next).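

In this assay, the step of a 1.1-fold higher number from compound 2 to compound 3 (0.04 log units; within the scatter) separates out thiophen-2-yl in place of 4-methylphenyl on a sulfonyl sulfur, while the step of a 1.0-fold lower number from compound 1 to compound 3 (0.02 log units; within the scatter) separates out (thiophen-2-yl)sulfonyl in place of (thiophen-2-yl)carbonyl on an amine nitrogen. The earlier step between compound 1 and compound 2 carried both swaps at once; read singly, neither goes beyond the scatter, so that combined result did not conceal two large opposing steps. No evidence bearing on this result is available.

Still open, from the compounds shown here alone, is whether an amine or a carboxylic acid in place of the thiophen-2-yl on a sulfonyl sulfur would give a step beyond the scatter. Also open, going by these compounds, is what a longer chain in place of the dodecyl chain would do to the number in this assay.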